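The source may report more compounds than this note shows. Statements on the series, on what has been measured and on what is new or still open speak of the compounds shown alone.

Compound 1 `CC(=O)c1cccc(-c2ccc(C(=O)N(Cc3cccc(OCCCCCC(=O)O)c3)C(C)C)cc2)c1` sits in an ADME assay on HepG2 cells (Homo sapiens) for cytotoxicity, read by CellTiter-Glo and resazurin assay, with a stated time of 72 h (on this read-out higher numbers stand for an effect only at larger amounts of compound and lower numbers for an effect already at smaller amounts), at the limit > 26000 nM, a limit and not a number.
Compound 2 `COc1cccc(-c2ccc(C(=O)N(Cc3cccc(OCCCCCC(=O)O)c3)C(C)C)cc2)c1` sits in this assay at the limit > 26000 nM.
Compound 3 `CCOC(=O)CCCCCOc1cccc(CN(C(=O)c2ccc(-c3cccc(C(C)=O)c3)cc2)C(C)C)c1` sits in this assay at the limit > 26000 nM.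

Compound 3 therefore stands where the two other compounds stand: only a limit is known for it, and no number. The two measured steps touch it from either side. The step that the two limits leave unreadable from compound 1 to compound 2 cannot be sized, and the step that the two limits leave unreadable from compound 1 to compound 3 cannot be sized either, because the limit of > 26000 nM in this assay, at which 3 of the 3 values shown sit, applies to every value shown.

Compound 4 `CCOC(=O)CCCCCOc1cccc(CN(C(=O)c2ccc(-c3cc(OC)ccc3F)cc2)C(C)C)c1` differs from compound 3 in one place: 2-fluoro-5-methoxyphenyl in place of 3-acetylphenyl on an aromatic carbon. Among the compounds with values here, of the measured steps, the one from compound 1 to compound 2 also swaps the group on that aromatic carbon, but its size is not readable, so nothing measured tells how large a step to expect in this assay, nor in which direction. With all three known compounds at the limit, the step from compound 3 to compound 4 is expected to be a step that the limit leaves unreadable from compound 3 to compound 4, nothing beyond the scatter.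

Compound 4 is thus estimated in this assay at 35000 nM, between 15000 nM and 90000 nM, most likely reported again as a limit.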

Compound 4, half-maximal effective concentration: > 26000 nM
Compound 4 was reported as a limit (the forecaster's own chance of this, stated with the estimate: 85%); the middle value does not contradict the limit.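

No size can be read for the change from compound 3 to compound 4, because both values are limits and not numbers: the limit of > 26000 nM in this assay, at which 4 of the 4 values shown sit. The compounds shown leave open where any of them would reach a half-maximal effect in this assay, and whether 2-fluoro-5-methoxyphenyl in place of 3-acetylphenyl shifts that point.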